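The compounds below may be only part of what the source reports. "The series", "measured", "known", "first", "only" and "open" are said of these compounds alone.

In a functional assay on NCI/ADR-RES cells (Homo sapiens) for antiproliferative activity, read by MTT assay, with a stated time of 48 h (a lower number here means a stronger inhibitor, a higher number a weaker inhibitor), compound 1 (`C=C1[C@H](OC(C)=O)[C@@H](OC(C)=O)[C@@H](O)C(C)(C)/C=C/[C@H](C)[C@H](OC(=O)c2ccccc2)[C@@]2(O)C[C@@](C)(O)[C@H](OC(C)=O)[C@@H]2[C@H]1OCC(C)C`) gives > 100000 nM as a limit of the assay, not a number. Compound 2 (`C=C1[C@H](OC(C)=O)[C@@H](OC(C)=O)[C@@H](OC(C)=O)C(C)(C)/C=C/[C@H](C)[C@H](OC(=O)c2ccccc2)[C@@]2(O)C[C@@](C)(O)[C@H](OC(C)=O)[C@@H]2[C@H]1OCC(C)C`) likewise gives only a limit, > 100000 nM, on the same scale. That is the limit of > 100000 nM in this assay, at which 2 of the 3 values shown sit, so compound 2 has no measured potency to start from. Between these two lies a step that the two limits leave unreadable from compound 1 to compound 2, and it therefore offers no size to carry forward.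

Compound 4 (`C=C1[C@H](OC(C)=O)[C@@H](OC(=O)c2cccc(C)c2)[C@@H](OC(C)=O)C(C)(C)/C=C/[C@H](C)[C@H](OC(=O)c2ccccc2)[C@@]2(O)C[C@@](C)(O)[C@H](OC(C)=O)[C@@H]2[C@H]1OCC(C)C`) differs from compound 2 by 3-methylphenyl in place of methyl on a carbonyl carbon in one place: 3-methylphenyl in place of methyl on a carbonyl carbon, which turns an acetyl into a (3-methylphenyl)carbonyl.

Among the compounds with values here, no measured step covers this change directly. The nearest evidence is compound 3 (`C=C1[C@H](OC(=O)c2cccc(C)c2)[C@@H](O)[C@@H](O)C(C)(C)/C=C/[C@H](C)[C@H](OC(=O)c2ccccc2)[C@@]2(O)C[C@@](C)(O)[C@H](OC(C)=O)[C@@H]2[C@H]1OCC(C)C`), which also carries a (3-methylphenyl)carbonyl and gives a real number, 33600 nM, in this assay. Compound 3 differs from compound 4 in more than that group, however, so this support is thin.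

The expected move is an at least 2.5-fold lower number from compound 2 to compound 4 (0.39 log units; beyond the scatter) towards a stronger inhibitor, with its size uncertain. For compound 4 the value is estimated at 40000 nM, with an expected range from 12000 nM to 100000 nM and a real chance that only a limit is reported.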

Compound 4, half-maximal inhibitory concentration: > 100000 nM
Compound 4: no number, only a limit (the forecaster's own chance of this, stated with the estimate: 40%); at least 2.5-fold (0.39 log units) between middle value and limit.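

In this assay compound 4 gives > 100000 nM, a limit of the assay and not a number. Compound 2 and compound 4 both rest at a limit, so no step between them can be read: the limit of > 100000 nM in this assay, at which 3 of the 4 values shown sit.

The compounds shown leave open whether 3-methylphenyl in place of methyl on this carbonyl carbon changes potency at all.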